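Methyl Loss on a Fused Core in a Growth Assay

The compounds below may be only part of what the source reports. "The series", "measured", "known", "first", "only" and "open" are said of these compounds alone.

Compound 1, `COc1ccc(-c2cc(O)c3cccnc3n2)cc1`, gives 17800 nM in a functional assay on HCT-116 cells (Homo sapiens); on this read-out lower numbers stand for stronger inhibition of growth and higher numbers for weaker inhibition of growth.
Compound 2, `COc1ccccc1-c1cc(O)c2ccc(C)nc2n1`, gives 38000 nM in this assay.
Compound 3, `COc1ccc(-c2cc(O)c3cc(C)cnc3n2)cc1`, gives 4170 nM in this assay.

Compound 3 and compound 1 differ by hydrogen in place of methyl on an aromatic carbon, and that step gives a 4.3-fold higher number from compound 3 to compound 1 (0.63 log units; beyond the scatter). Compound 2 and compound 3 hold the same atoms joined differently; the difference between the two cores is not broken down here. Compound 4, `COc1ccccc1-c1cc(O)c2cccnc2n1`, is not yet measured and differs from compound 2 by hydrogen in place of methyl on an aromatic carbon. The places are not the same word for word: in the measured pair the methyl stands two atoms from the ring nitrogen, in the new pair next to the ring nitrogen, so this is the same kind of change, not the same change. In this assay compound 4 is expected to give a weaker result than compound 2, an expected step of a 2.4-fold higher number from compound 2 to compound 4 (0.37 log units; beyond the scatter), because the earlier step of a 4.3-fold higher number from compound 3 to compound 1 (0.63 log units; beyond the scatter) went in that direction. The estimate for compound 4 is 90000 nM, between 35000 nM and 250000 nM.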

Compound 4, concentration for 50% growth inhibition: 27500 nM
The estimate for compound 4 lay 3.3-fold (0.51 log units) above the measured number; the measured number lies below the stated range.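

In this assay, hydrogen in place of methyl on an aromatic carbon gives a 1.4-fold lower number from compound 2 to compound 4 (0.14 log units; within the scatter), so this pair cannot be told apart on this read-out. The change therefore did not carry a single effect from one core to the other: the same change on two cores in this assay, a 4.3-fold higher number (0.63 log units; beyond the scatter) from compound 3 to compound 1 and a 1.4-fold lower number (0.14 log units; within the scatter) from compound 2 to compound 4, 5.9-fold (0.77 log units) apart, beyond the scatter of two such steps This shows that the step on one core could not be transferred to the other here, but two pairs, with the methyl in a different place in each, do not show whether the core or the place accounts for the gap.

The compounds shown leave open how an amine or a carboxylic acid in the place of the methyl would read in this assay. They also leave open whether a longer chain there would separate from methyl on either core.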